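The source may hold more compounds than are shown below. What is called first, only, known or untested is meant among the compounds shown, and "the series" means these compounds.

Among the measured compounds shown here, in a functional assay on P388 cells (Mus musculus) for cytotoxicity (a higher number here means a weaker inhibitor, a lower number a stronger inhibitor), compound 2 `CC/C=C/CN1C(=O)[C@@H](C)NC(=O)[C@@H]2Cc3ccc(OC)c(c3)Oc3ccc(cc3)C[C@@H](C(=O)N2C)N(C)C(=O)[C@H](C)NC(=O)[C@H](Cc2ccc(OC)cc2)N(C)C(=O)[C@@H]1C` gives 12 nM and stands level with its only measured neighbour, compound 1 `CCCCN1C(=O)[C@@H](C)NC(=O)[C@@H]2Cc3ccc(OC)c(c3)Oc3ccc(cc3)C[C@@H](C(=O)N2C)N(C)C(=O)[C@H](C)NC(=O)[C@H](Cc2ccc(OC)cc2)N(C)C(=O)[C@@H]1C`, which gives 12 nM in the same test. These two differ in a single place, where but-1-en-1-yl takes the place of propyl on a saturated chain carbon bound to an amide-type nitrogen in a ring.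

Compound 3 `COc1ccc(C[C@H]2C(=O)N[C@@H](C)C(=O)N(C)[C@H]3Cc4ccc(cc4)Oc4cc(ccc4OC)C[C@@H](C(=O)N[C@H](C)C(=O)N(CC=C(C)C)[C@@H](C)C(=O)N2C)N(C)C3=O)cc1` changes that same place again, and its atoms are the same as those of compound 2 but joined differently: 2-methylprop-1-en-1-yl in place of but-1-en-1-yl on a saturated chain carbon bound to an amide-type nitrogen in a ring. In words, 2-methylprop-1-en-1-yl replaces but-1-en-1-yl, so the chain gains a branch while keeping its double bond.

For the measured compounds named here, only one measured step bears on this place, namely no change at the digits printed from compound 1 to compound 2 (within the scatter). It was a different swap, so it is a loose guide, and no data yet show how branching here behaves. On that evidence, no shift beyond the scatter is expected in this assay in either direction. The estimated step is no change at the digits printed from compound 2 to compound 3 (within the scatter). For compound 3 the expected value is 12 nM within an estimated range of 5 nM to 30 nM.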

Compound 3, half-maximal inhibitory concentration: 6.92 nM
Beside the measured number, compound 3's estimate is 1.7-fold (0.24 log units) above it, and the stated range covers the measured number.
By their numbers in this assay, from the lowest: compounds 3, 1 and 2 (each within the scatter of the next).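

Branching is the new information here: in this assay the step to the branched chain reads a 1.7-fold lower number from compound 2 to compound 3 (0.24 log units; within the scatter) and stays small, even though the atoms are the same and only their joining differs. Set against the saturated chain, the same branched group reads a 1.7-fold lower number from compound 1 to compound 3 (0.24 log units; within the scatter) and again stays within the noise of the test, so propyl, but-1-en-1-yl and 2-methylprop-1-en-1-yl all read alike on this saturated chain carbon bound to an amide-type nitrogen in a ring, and none of the three compounds goes against that. The data shown offer no measurement that could explain why this place accepts all three chains.

On these data alone, all three groups are small hydrocarbon chains, so it remains open how far this tolerance reaches, for instance to a much longer chain such as octyl, to a benzyl group, or to a chain ending in an amine or a carboxylic acid. As far as these compounds go, it is also open whether any group at this place can move the number beyond the scatter in either direction, since every step seen so far lies within it.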